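Trading a Phenol for a Chlorophenyl Group

The compounds below may be only part of what the source reports. "The series", "measured", "known", "first", "only" and "open" are said of these compounds alone.

Of the compounds shown here, two sharing one core have been measured. In a functional assay for inhibition, tested at 100 ug/mL (on this read-out higher numbers stand for a stronger effect at the one concentration tested and lower numbers for a weaker effect), compound 1 `COc1cc(-c2cc(-c3cc(C(C)C)c(O)cc3C)[nH]c(=O)c2C#N)ccc1O` gives 44%, and in this assay compound 2 `COc1cc(OC)c(-c2cc(-c3cc(C(C)C)c(O)cc3C)[nH]c(=O)c2C#N)c(OC)c1` gives 82.5%. Compound 1 thus holds the lower of the two numbers, and compound 2 stands above it by more than the usual scatter. Compound 3 `Cc1cc(O)c(C(C)C)cc1-c1cc(-c2ccccc2Cl)c(C#N)c(=O)[nH]1` has not yet been measured. It differs from compound 1 in one place: 2-chlorophenyl in place of 4-hydroxy-3-methoxyphenyl on an aromatic carbon. Going by the values given here, no measured pair shows an exchange of this kind, so the direction of the step cannot be read from the data at hand; the two measured values show only that the group on this carbon can shift the read-out considerably, as compound 2 does relative to compound 1. The step of a number 6 percentage points higher from compound 1 to compound 3 (within the scatter) is expected to be modest, quite possibly none beyond the scatter. Compound 3 is therefore estimated at 50%, within a wide range from 20% to 80%.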

Compound 3, a percentage reported as inhibition, at one concentration (the size of the read-out at that concentration, not a potency): 34%
Estimate against measurement, compound 3: 16 percentage points above; low and high end bracket the measured number.
By their numbers in this assay, from the lowest: compounds 3 and 1 (each within the scatter of the next); then compound 2.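

In this assay, the exchange of 4-hydroxy-3-methoxyphenyl for 2-chlorophenyl on this aromatic carbon, ortho to a cyano group and opposite the ring nitrogen, comes out as a number 10 percentage points lower from compound 1 to compound 3 (within the scatter) and so does not separate the two compounds. The entering group counts 0 hydrogen-bond donors and 0 hydrogen-bond acceptors, yet compound 3 gives 34% and remains within the scatter of compound 1, so this pair shows that a read-out at this level does not depend on the hydroxy and methoxy groups of the leaving ring. Nothing available explains why these two groups read alike.

The compounds shown leave open how 4-chlorophenyl or plain phenyl would read on this carbon, which would test whether the chlorine and its place on the ring count. They also leave open how an aminophenyl or a carboxylic acid on that ring would read.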